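A few compounds are considered here, and "the series" means these few. Any claim that something is new, unique, unknown or untested is made for them only; others in the source may bear on it.

Measured so far in an assay on HEK293 cells for inhibition of acid ceramidase (Homo sapiens), read by fluorescence, with stated times of 10 min and 3 h; a higher number here means a weaker inhibitor, a lower number a stronger inhibitor:
- compound 1 `CCOCCNC(=O)n1c(=O)oc2cc(C3CCN(C)CC3)ccc21` — 1050 nM
- compound 2 `CN1CCc2oc(=O)n(C(=O)NCCCCc3ccccc3)c2C1` — 516 nM

Compound 1 stands as the higher of the two numbers in this assay; compound 2 gives the lower number, and the gap between them lies beyond the usual scatter. The two compounds differ in more than one place, so no single step can be read from that gap.

Compound 3 `CCCCCNC(=O)n1c(=O)oc2cc(C3CCN(C)CC3)ccc21` is the next compound to be measured in this assay. It differs from compound 1 in one place: propyl in place of ethoxy on a saturated chain carbon, two bonds along the chain from an amide-type nitrogen. The acceptor counted in the ethoxy group is lost and an all-carbon chain of the same length takes its place.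

Within the data shown here, no matched pair among the measured compounds shows what this exchange does, so the expectation rests on the structural change alone. The step from compound 1 to compound 3 is expected to be small, a modest lowering of the number, close to the scatter, written as a 1.6-fold lower number from compound 1 to compound 3 (0.21 log units; within the scatter). Compound 3 is accordingly estimated at 650 nM, with a range from 250 nM to 1700 nM.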

Compound 3, half-maximal inhibitory concentration: 396 nM
Compound 3: middle estimate off by 1.6-fold (0.22 log units), on the high side, and the stated range covers the measured number.
By their numbers in this assay, from the lowest: compounds 3 and 2 (each within the scatter of the next); then compound 1.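

In this assay, among these compounds, the exchange of ethoxy for propyl on a saturated chain carbon, two bonds along the chain from an amide-type nitrogen, gives a 2.7-fold lower number from compound 1 to compound 3 (0.42 log units; beyond the scatter), the first step that can be read at a single place. On the core of compound 1, the side chain therefore keeps a number in this range without the hydrogen-bond acceptor counted in the ethoxy group, and the all-carbon pentyl chain, with the same count of heavy atoms as the 2-ethoxyethyl chain, gives the lower number. No measurement shown accounts for the size or direction of this step.

This one pair cannot separate the loss of the oxygen from any other difference between the two chains, and it does not show whether the step would hold on another core. Going by these compounds, how the number responds to a longer chain such as heptyl, to a terminal amine or carboxylic acid on the chain, or to a cyclohexyl group at its end remains open.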